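Working notes: 4-chlorobutyl to propargyl on the shared core

This account rests on a few compounds, and the source may have more. Where it says the series, first, only, none or still open, it means among the compounds named here.

In a functional assay on MCF7 cells (Homo sapiens) for inhibition (on this read-out higher numbers stand for weaker inhibition and lower numbers for stronger inhibition), compound 1 (`CCCCCC[C@@]1(C)SC(O)=CC1=O`) gives 16.5 ug/mL. Under the same read-out, compound 2 (`C=CCC1=C(O)S[C@](C)(CCCCCCCC)C1=O`) gives 34.8 ug/mL and compound 3 (`CCCCCC[C@@]1(C)SC(=O)C=C1OCCCCCl`) gives 8.6 ug/mL. Compound 3 stands within the scatter of compound 1 and beyond the scatter of compound 2, whose number is the higher of that pair.

Within the data shown here, compound 4 (`C#CCOC1=CC(=O)S[C@]1(C)CCCCCC`) has no measurement yet. Its difference from compound 3 is ethynyl in place of 3-chloropropyl on a saturated chain carbon bound to an oxygen on an unsaturated carbon, which also reads as 4-chlorobutoxy to propargyloxy.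

Among the measured compounds shown here, no measured pair isolates this change, so the expectation rests on thin ground. With compound 3 at 8.6 ug/mL and compound 1 at 16.5 ug/mL, no large shift is expected in this assay. The expected outcome is a 1.4-fold higher number from compound 3 to compound 4 (0.14 log units; within the scatter), a modest move toward a higher number and not beyond the scatter. Compound 4 is estimated at 12 ug/mL, with an expected range of 5 ug/mL to 30 ug/mL.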

Compound 4, half-maximal inhibitory concentration: 21.9 ug/mL
Compound 4: middle estimate off by 1.8-fold (0.26 log units), on the low side; low and high end bracket the measured number.
By their numbers in this assay, from the lowest: compounds 3, 1, 4 and 2 (each within the scatter of the next, the first and the last beyond it).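

On the saturated chain carbon bound to an oxygen on an unsaturated carbon, the swap of 3-chloropropyl for ethynyl gives in this assay a 2.5-fold higher number from compound 3 to compound 4 (0.41 log units; beyond the scatter) on the shared core. Among these compounds, this is the only pair that differs in one place, and it shows that this position does not tolerate the change silently: 4-chlorobutoxy carries the lower number and propargyloxy the higher one. Nothing measured here bears on the reason for this step.

The pair leaves open whether the step follows the chlorine, the chain length or the triple bond, as all three change together. A plain butoxy group, a propoxy group or a terminal amine on the same chain would separate these, and a single pair cannot say whether the step holds on other cores.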